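Swapping a Chlorophenyl for a Difluorophenyl on the Ring Nitrogen

This account rests on a few compounds, and the source may have more. Where it says the series, first, only, none or still open, it means among the compounds named here.

Within the data shown here, compound 2 `COc1cc2c(Oc3ccc(NC(=O)c4nn(-c5ccc(Cl)cc5)c(=O)cc4C)cc3F)ccnc2cc1OCCCN1CCN(C)CC1` gives 270 nM in a functional assay on A549 cells (Homo sapiens) for inhibition, read by MTT assay, with a stated time of 72 h (on this read-out higher numbers stand for weaker inhibition and lower numbers for stronger inhibition), the lowest of the two numbers recorded so far; the only other measured compound, compound 1 `COc1cc2c(Oc3ccc(NC(=O)c4nn(-c5ccccc5C)c(=O)cc4C)cc3F)ccnc2cc1OCCCN1CCN(C)CC1`, gives 2830 nM in this assay. Among the measured compounds shown here, the single measured step, a 10-fold lower number from compound 1 to compound 2 (1.02 log units; beyond the scatter), exchanges a 2-methylphenyl for a 4-chlorophenyl on the aromatic nitrogen and is large. Compound 3 `COc1cc2c(Oc3ccc(NC(=O)c4nn(-c5ccc(F)c(F)c5)c(=O)cc4C)cc3F)ccnc2cc1OCCCN1CCN(C)CC1` differs from compound 2 by 3,4-difluorophenyl in place of 4-chlorophenyl on an aromatic nitrogen. That earlier step shows the substituent on this aromatic nitrogen can move the number strongly, but it compares a different pair of groups, so it only loosely bears on the present change, in which one halogenated phenyl replaces another. For the measured compounds named here, no step within the scatter or a modest loss is expected. Compound 3 is therefore estimated at 420 nM in this assay, with a range of 150 nM to 1200 nM, which would mean an expected step of a 1.6-fold higher number from compound 2 to compound 3 (0.19 log units; within the scatter).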

Compound 3, half-maximal inhibitory concentration: 130 nM
Beside the measured number, compound 3's estimate is 3.2-fold (0.51 log units) above it, outside the stated range (below it).
By their numbers in this assay, from the lowest: compound 3; then compound 2; then compound 1.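

In this assay, the exchange of 4-chlorophenyl for 3,4-difluorophenyl on the aromatic nitrogen gives a 2.1-fold lower number from compound 2 to compound 3 (0.32 log units; beyond the scatter) and shows that the number at this position still moves beyond the scatter when one halogenated phenyl replaces another, although the step is modest. Measured against the 2-methylphenyl group, the same 3,4-difluorophenyl group gives a 22-fold lower number from compound 1 to compound 3 (1.34 log units; beyond the scatter) and places compound 3 lowest of the three, with both of its steps beyond the scatter. Nothing available here accounts for these differences.

This change alters both the halogen and the number of halogens at once, so the compounds shown cannot separate the two. They also leave open how this position would respond to a phenyl group carrying an amine, a carboxylic acid or a methoxy group.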